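This account rests on a few compounds, and the source may have more. Where it says the series, first, only, none or still open, it means among the compounds named here.

Measured so far:
Compound 1, `Oc1ccc(Nc2nc(-c3ccc(F)cc3)cs2)cc1`: 700 nM in an assay on isolated protein for inhibition of Polyunsaturated fatty acid 5-lipoxygenase (Homo sapiens), with stated times of 15 min and 10 min; on this read-out lower numbers stand for stronger inhibition and higher numbers for weaker inhibition
Compound 2, `Cc1ccc(-c2csc(Nc3ccc(O)cc3)n2)cc1`: 900 nM in this assay

Going by the values given here, compound 1 and compound 2 give numbers within the usual scatter of each other; the only measured step, a 1.3-fold higher number from compound 1 to compound 2 (0.11 log units; within the scatter), changes the fluoro on the second aromatic ring. Compound 3, `CC(=O)c1ccc(Nc2nc(-c3ccc(F)cc3)cs2)cc1`, differs from compound 1 elsewhere: acetyl in place of hydroxy on an aromatic carbon. Among the compounds with values here, no measured step touches the hydroxy, so nothing here tells how large this change will be. Compound 3 is estimated at about 2500 nM in this assay, within 600 nM to 10000 nM. That expected step, a 3.6-fold higher number from compound 1 to compound 3 (0.55 log units; beyond the scatter), would be a weakening beyond the scatter.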

Compound 3, half-maximal inhibitory concentration: 4900 nM
Beside the measured number, compound 3's estimate is 2.0-fold (0.29 log units) below it, and the stated range covers the measured number.
By their numbers in this assay, from the lowest: compounds 1 and 2 (each within the scatter of the next); then compound 3.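

Changes at this position can move the number beyond the scatter, which the fluoro-to-methyl step on the other aromatic ring did not show: acetyl in place of hydroxy gives a 7.0-fold higher number from compound 1 to compound 3 (0.85 log units; beyond the scatter) in this assay. The change removes a hydrogen-bond donor and adds heavy atoms at once, so this single step cannot separate the two differences. No evidence here explains the rise.

On these data alone, whether an amine or a methoxy group in place of the hydroxy would keep the number close to that of compound 1 remains open. So does the outcome with a carboxylic acid at this position.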